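This account rests on a few compounds, and the source may have more. Where it says the series, first, only, none or still open, it means among the compounds named here.

Notes on the series.

Compound 1 `CCOc1ccc(Cc2nnc(CN(c3ccccc3CC)S(=O)(=O)c3ccc(C)cc3)o2)cc1` gives 126 nM in an assay on CHO cells for displacement of a labelled ligand from prostaglandin E2 receptor EP1 subtype (Homo sapiens); a higher number here means a weaker inhibitor, a lower number a stronger inhibitor. Compound 2 `CCOc1ccc(Cc2nnc(CN(c3cccc(Cl)c3C)S(=O)(=O)c3ccc(C)cc3)o2)cc1` differs from compound 1 in one place: 3-chloro-2-methylphenyl in place of 2-ethylphenyl on a sulfonamide nitrogen. In this assay compound 2 gives 3.98 nM, a step of a 32-fold lower number from compound 1 to compound 2 (1.50 log units; beyond the scatter). Compound 3 `CCc1ccccc1N(Cc1nnc(CNc2ccc(OC)cc2)o1)S(=O)(=O)c1ccc(C)cc1` differs from compound 1 in its core: (4-methoxyphenyl)amino in place of 4-ethoxyphenyl on a saturated chain carbon bound to an aromatic carbon. In this assay compound 3 gives 501 nM, which is a 4.0-fold higher number from compound 1 to compound 3 (0.60 log units; beyond the scatter). Among the three measured compounds, compound 3 gives the highest number, and its gap to compound 2 is the widest in the set.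

Compound 4 `COc1ccc(NCc2nnc(CN(c3cccc(Cl)c3C)S(=O)(=O)c3ccc(C)cc3)o2)cc1` has not been measured. It stands to compound 3 as compound 2 stands to compound 1: 3-chloro-2-methylphenyl in place of 2-ethylphenyl on a sulfonamide nitrogen. The place is the same word for word, a sulfonamide nitrogen whose other neighbours are a saturated chain carbon and a sulfonyl sulfur, so this is the same change, here made on the core of compound 3 instead of the core of compound 1. Going by the values given here, the only precedent is the single pair of compound 1 and compound 2, so the expectation rests on one step. From the compounds shown here alone, a step of a size near a 32-fold lower number from compound 1 to compound 2 (1.50 log units; beyond the scatter) is expected, though tempered, since how far it carries onto the core of compound 3 is untested. The expected step for compound 4 is a 25-fold lower number from compound 3 to compound 4 (1.40 log units; beyond the scatter). Compound 4 is estimated at 20 nM in this assay, with a range from 5 nM to 80 nM.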

Compound 4, half-maximal inhibitory concentration: 20 nM
Compound 4: the middle estimate sits on the measured number at the digits printed; low and high end bracket the measured number.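

Carried onto the core of compound 3, 3-chloro-2-methylphenyl in place of 2-ethylphenyl on the sulfonamide nitrogen gives a 25-fold lower number from compound 3 to compound 4 (1.40 log units; beyond the scatter) in this assay, and the step keeps its size from one core to the other: the same change on two cores in this assay, a 32-fold lower number (1.50 log units; beyond the scatter) from compound 1 to compound 2 and a 25-fold lower number (1.40 log units; beyond the scatter) from compound 3 to compound 4, 1.3-fold (0.10 log units) apart, within the scatter of two such steps.

The same square read along its other side gives a 5.0-fold higher number from compound 2 to compound 4 (0.70 log units; beyond the scatter) for (4-methoxyphenyl)amino in place of 4-ethoxyphenyl, so this change also holds its size whichever group sits on the sulfonamide nitrogen: the same change on two cores in this assay, a 4.0-fold higher number (0.60 log units; beyond the scatter) from compound 1 to compound 3 and a 5.0-fold higher number (0.70 log units; beyond the scatter) from compound 2 to compound 4, 1.3-fold (0.10 log units) apart, within the scatter of two such steps.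

This shows that the two changes behave independently within these four compounds, but it rests on a single square of two cores and two aryl groups, so it is no rule for the series and gives no reason for the size of either step.

Still open, from the compounds shown here alone, is whether the step survives on cores bearing something else in place of 4-ethoxyphenyl or (4-methoxyphenyl)amino, such as a carboxylic acid, an amine or a longer alkyl chain. The change also swaps ethyl for methyl and adds chlorine in one move, so a 3-chlorophenyl or a 2-methylphenyl group on the sulfonamide nitrogen would be needed to tell how much of the step belongs to each part.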